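Swapping a bromophenyl group on a shared core

A few compounds are considered here, and "the series" means these few. Any claim that something is new, unique, unknown or untested is made for them only; others in the source may bear on it.

Among the compounds with values here, in a functional assay on NCI-H460 cells (Homo sapiens) for antiproliferative activity, read by MTT assay, with a stated time of 48 h (on this read-out higher numbers stand for weaker inhibition and lower numbers for stronger inhibition), compound 1 `COc1ccc(-c2nc3cccc(-c4cc(OC)c(OC)c(OC)c4)c3o2)cc1` gives 3500 nM and compound 2 `COc1cc(-c2cccc3nc(-c4cccc(Br)c4)oc23)cc(OC)c1OC` gives 3800 nM, so compound 2 stands within the scatter of the only other measured compound. Compound 3 `COc1cc(-c2cccc3nc(-c4ccc(Br)cc4)oc23)cc(OC)c1OC` differs from compound 2 in one place: 4-bromophenyl in place of 3-bromophenyl on an aromatic carbon, with 4-bromophenyl in place of 3-bromophenyl on an aromatic carbon. Within the data shown here, the one measured step, a 1.1-fold higher number from compound 1 to compound 2 (0.04 log units; within the scatter), changed the group at that same place and stayed within the scatter. No change beyond the scatter is therefore expected in this assay, and the expected step, a 1.1-fold lower number from compound 2 to compound 3 (0.04 log units; within the scatter), is small. For compound 3 the estimated value is 3500 nM, with an expected range of 1500 nM to 8000 nM.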

Compound 3, half-maximal inhibitory concentration: > 25000 nM
Compound 3: no number, only a limit (the forecaster's own chance of this, stated with the estimate: 8%); at least 7.1-fold (0.85 log units) between middle value and limit.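

Position matters at this carbon: 4-bromophenyl in place of 3-bromophenyl, with the same atoms joined differently, gives an at least 6.5-fold higher number from compound 2 to compound 3 (0.81 log units; beyond the scatter) in this assay. Compound 3 also parts from compound 1, with an at least 7.1-fold higher number from compound 1 to compound 3 (0.85 log units; beyond the scatter), so this place does not accept every aryl group as the first two compounds suggested. Compound 3 has no number here, only a limit of the assay: the limit of > 25000 nM in this assay, at which 1 of the 3 values shown sits.

Going by these compounds, whether a phenyl ring carrying an amine or a carboxylic acid in place of bromine would behave like compound 2 or compound 3 stays open. These data cannot tell why moving the bromine has this effect.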